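Pyrazole series: methoxy for hydroxy, amide versus urea

The source may report more compounds than this note shows. Statements on the series, on what has been measured and on what is new or still open speak of the compounds shown alone.

Measured compounds:
compound 1, `O=C(Nc1cccc(-n2cc(-c3ccncc3)c(-c3cc(O)cc(Cl)c3)n2)c1)Nc1ccc(Cl)c(C(F)(F)F)c1`, 8.81%
compound 2, `COc1cc(Cl)cc(-c2nn(-c3cccc(NC(=O)Nc4ccc(Cl)c(C(F)(F)F)c4)c3)cc2-c2ccncc2)c1`, 5.2%
compound 3, `O=C(Nc1cccc(-n2cc(-c3ccncc3)c(-c3cc(O)cc(Cl)c3)n2)c1)c1cc(C(F)(F)F)cc(C(F)(F)F)c1`, 27.3%

All three were run in a functional assay on A549 cells (Homo sapiens) for inhibition, read by sulforhodamine B assay, with a stated time of 48 h, tested at 10 uM; a higher number here means a weaker effect of the compound at the concentration tested, a lower number a stronger effect. Compound 1 gives 8.81% and compound 2 gives 5.2%; the two differ by one change, (methyl in place of hydrogen on an oxygen on an aromatic ring), and the step is a number 3.6 percentage points lower from compound 1 to compound 2 (within the scatter). Compound 3 gives 27.3%, the highest of the three numbers, beyond the scatter from both compound 1 and compound 2. Compound 3 carries an amide in place of the urea of compound 1; the difference between the two cores is not broken down here.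

Compound 4, `COc1cc(Cl)cc(-c2nn(-c3cccc(NC(=O)c4cc(C(F)(F)F)cc(C(F)(F)F)c4)c3)cc2-c2ccncc2)c1`, has not been measured. It differs from compound 3 by methyl in place of hydrogen on an oxygen on an aromatic ring, the same change as from compound 1 to compound 2, made this time on the amide core. The place of the change is the same word for word in both pairs.

Expectation: since the earlier step was a number 3.6 percentage points lower from compound 1 to compound 2 (within the scatter), a step of similar size is expected from compound 3 to compound 4, namely a number 3.3 percentage points lower from compound 3 to compound 4 (within the scatter), resting on that single measured pair only; the core differs, so a larger move cannot be excluded. Compound 4 is therefore estimated at 24% in this assay, with a likely range from 9% to 40%.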

Compound 4, a percentage reported as activity, at one concentration (the size of the read-out at that concentration, not a potency): 43.5%
The estimate for compound 4 lay 19.5 percentage points below the measured number, and the stated range ends below it.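

In this assay the change from hydroxy to methoxy on the 3-chloro-5-hydroxyphenyl group has a clear effect on the amide core, with the reading moving by a number 16.2 percentage points higher from compound 3 to compound 4 (beyond the scatter) and so pointing to a weaker effect for the methoxy compound at the concentration tested. The change therefore cannot be carried from one core to the other in this series as a step of fixed size or even of fixed direction: the same change on two cores in this assay, a number 3.6 percentage points lower (within the scatter) from compound 1 to compound 2 and a number 16.2 percentage points higher (beyond the scatter) from compound 3 to compound 4, 19.8 percentage points apart, beyond the scatter of two such steps. Among the compounds shown here, this does not show which feature of the cores is responsible, since compound 1 and compound 3 differ both in urea versus amide and in the substituents of the terminal phenyl ring, and each core contributes only a single pair read at a single concentration, which gives no potency.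

Still open, as far as these compounds go, is whether the amide or the two trifluoromethyl groups govern the step, a question that a urea carrying the same two trifluoromethyl groups could separate. Also open, from the compounds shown here alone, is how an amine, or a longer chain such as ethoxy, in place of the hydroxy would read on each core, and whether any such step would follow the same dependence on the core.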